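This account rests on a few compounds, and the source may have more. Where it says the series, first, only, none or still open, it means among the compounds named here.

In an ADME assay on microsomes from liver (Homo sapiens) for metabolic stability, with a stated time of 10 min (on this read-out lower numbers stand for a less stable compound and higher numbers for a more stable compound), compound 2 `O=C(NS(=O)(=O)CCNCc1ccccc1)c1ccc(Nc2nc(NC3(c4ccc(Cl)cc4)CC3)nc(OCC(F)(F)F)n2)cc1` gives 99%, and compound 1 `CC(C)NC(=O)NCCS(=O)(=O)NC(=O)c1ccc(Nc2nc(NC3(c4ccc(Cl)cc4)CC3)nc(OCC(F)(F)F)n2)cc1` gives 100%; the two values sit within the usual scatter of each other, both close to full recovery. Among the compounds with values here, the one measured step, a number 1 percentage points lower from compound 1 to compound 2 (within the scatter), swaps a group on the amine nitrogen of the side chain without moving the read-out. Compound 3 `CN(C)S(=O)(=O)NC(=O)c1ccc(Nc2nc(NC3(c4ccc(Cl)cc4)CC3)nc(OCC(F)(F)F)n2)cc1` differs from compound 2 by dimethylamino in place of 2-(benzylamino)ethyl on a sulfonyl sulfur, a broader change than that single step, so direct guidance is limited. With both known values near the top of the scale, no shift beyond the scatter is expected, a number 4 percentage points lower from compound 2 to compound 3 (within the scatter). Compound 3 is therefore estimated at 95%, within 80% to 100%.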

Compound 3, percent of the compound remaining: 86%
Beside the measured number, compound 3's estimate is 9 percentage points above it; the measured number falls inside the stated range.
By their numbers in this assay, from the lowest: compound 3; then compounds 2 and 1 (each within the scatter of the next).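

In this assay the group on the sulfonyl sulfur does move the read-out: dimethylamino in place of the longer chains gives a number 13 percentage points lower from compound 2 to compound 3 (beyond the scatter) and also a number 14 percentage points lower from compound 1 to compound 3 (beyond the scatter) in this series. The earlier swap at the far end of the chain, on its amine nitrogen, gave no shift beyond the scatter. No measurement here explains the drop.

On these data alone, it remains open whether removing the longer chain or adding dimethylamino itself accounts for the lower number. A 2-aminoethyl chain or a morpholine on the sulfonyl sulfur would help separate the two.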